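This account rests on a few compounds, and the source may have more. Where it says the series, first, only, none or still open, it means among the compounds named here.

Working notes on the series

Three nucleoside analogues share a core and differ only in two peripheral substituents. Compound 1 `OC[C@H]1O[C@@H](n2cc(F)c3c(-c4ccoc4)ncnc32)[C@H](O)[C@@H]1O` carries fluoro and furan-3-yl; in an ADME assay on BJ cells (Homo sapiens) for cytotoxicity, read by MTT assay, with a stated time of 72 h (a higher number here means that more compound is tolerated, a lower number that less compound is tolerated), compound 1 gives 350 nM. Compound 2 `OC[C@H]1O[C@@H](n2cc(F)c3c(-c4cccs4)ncnc32)[C@H](O)[C@@H]1O` keeps the fluoro and differs from compound 1 in thiophen-2-yl in place of furan-3-yl on an aromatic carbon, and in this assay compound 2 gives 170 nM, a step of a 2.1-fold lower number from compound 1 to compound 2 (0.31 log units; beyond the scatter). Compound 3 `OC[C@H]1O[C@@H](n2cc(Cl)c3c(-c4ccoc4)ncnc32)[C@H](O)[C@@H]1O` keeps the furan-3-yl and differs from compound 1 in chloro in place of fluoro on an aromatic carbon; in this assay compound 3 gives 21600 nM, a step of a 62-fold higher number from compound 1 to compound 3 (1.79 log units; beyond the scatter). Compound 3 thus stands as the most tolerated of the three measured compounds, with both steps to it beyond the scatter.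

Compound 4 `OC[C@H]1O[C@@H](n2cc(Cl)c3c(-c4cccs4)ncnc32)[C@H](O)[C@@H]1O` has not yet been measured. It differs from compound 3 in thiophen-2-yl in place of furan-3-yl on an aromatic carbon, the same change seen between compound 1 and compound 2, set on a core that differs from that of compound 1 and compound 2 in chloro in place of fluoro on an aromatic carbon. Within the data shown here, only that one earlier instance of the change exists here, so whether it transfers to the chloro core is not yet known.

Beside the measured step of a 2.1-fold lower number from compound 1 to compound 2 (0.31 log units; beyond the scatter), the step from compound 3 to compound 4 is expected to be a 2.2-fold lower number from compound 3 to compound 4 (0.33 log units; beyond the scatter), resting on that single earlier pair and on the value of compound 3, 21600 nM. In this assay compound 4 is therefore estimated at 10000 nM, expected to fall between 4000 nM and 26000 nM.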

Compound 4, half-maximal cytotoxic concentration: 4970 nM
The estimate for compound 4 lay 2.0-fold (0.30 log units) above the measured number, within the range that was stated.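

In this assay, thiophen-2-yl in place of furan-3-yl on the core of compound 3 gives a 4.3-fold lower number from compound 3 to compound 4 (0.64 log units; beyond the scatter), and this step agrees in direction and, within the scatter, in size with the step on the core of compound 1: the same change on two cores in this assay, a 2.1-fold lower number (0.31 log units; beyond the scatter) from compound 1 to compound 2 and a 4.3-fold lower number (0.64 log units; beyond the scatter) from compound 3 to compound 4, 2.1-fold (0.32 log units) apart, within the scatter of two such steps. Read the other way round, chloro in place of fluoro with thiophen-2-yl in place gives a 29-fold higher number from compound 2 to compound 4 (1.47 log units; beyond the scatter), and this large step matches the one seen with furan-3-yl: the same change on two cores in this assay, a 62-fold higher number (1.79 log units; beyond the scatter) from compound 1 to compound 3 and a 29-fold higher number (1.47 log units; beyond the scatter) from compound 2 to compound 4, 2.1-fold (0.32 log units) apart, within the scatter of two such steps. Both changes therefore carried across the two cores in this square of four compounds, with the halogen change much the larger, but this rests on a single pair of steps for each change in one cell line and does not show that either change would carry to any core beyond these.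

The compounds shown leave open whether the same steps would hold with a phenyl ring or an amine in place of the five-membered aromatic ring. They also leave open where bromo or methyl in place of the halogen would fall, and whether the large gap between fluoro and chloro would appear at all with such groups.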